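Replacing a Pyrazole with a Methylthiazole in a 24-Hydroxylase Inhibitor

The compounds below may be only part of what the source reports. "The series", "measured", "known", "first", "only" and "open" are said of these compounds alone.

Of the compounds shown here, three have been measured in an assay on HEK293F cells for inhibition of cholesterol 24-hydroxylase (Homo sapiens), read by trypan blue exclusion, with stated times of 15 min and 5 h; a lower number here means a stronger inhibitor, a higher number a weaker inhibitor. Compound 1 `O=C(NC1CC1)c1ccc(-c2cnccc2-c2ccccc2)cc1` gives 74 nM, compound 2 `CCNC(=O)C1CCN(c2cncnc2-c2ccccc2)CC1` gives 58 nM, and compound 3 `CN(C)C(=O)C1CCN(c2cnccc2-n2cccn2)CC1` gives 48 nM. Compound 3 holds the lowest of the three numbers, but its gaps to compound 2 and to compound 1 both fall within the usual scatter of repeated measurements, so the three cannot be ranked against one another.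

Compound 4 `Cc1cnc(-c2ccncc2N2CCC(C(=O)N(C)C)CC2)s1` differs from compound 3 in one place: 5-methyl-1,3-thiazol-2-yl in place of 1H-pyrazol-1-yl on an aromatic carbon. Within the data shown here, no measured pair shows the effect of this exchange, so the size of the step has no precedent here. The amide and the saturated ring that carries it stay the same, and one five-membered aromatic ring replaces another. The step from compound 3 to compound 4 in this assay is therefore expected to be small, in either direction, and most likely not beyond the scatter: a 1.5-fold higher number from compound 3 to compound 4 (0.16 log units; within the scatter). On that basis compound 4 is estimated at 70 nM in this assay, with a range from 25 nM to 200 nM.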

Compound 4, half-maximal inhibitory concentration: 12 nM
The estimate for compound 4 lay 5.8-fold (0.77 log units) above the measured number; measured number below the stated range.
By their numbers in this assay, from the lowest: compound 4; then compounds 3, 2 and 1 (each within the scatter of the next).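

In this assay, putting 5-methyl-1,3-thiazol-2-yl in place of 1H-pyrazol-1-yl gives a 4.0-fold lower number from compound 3 to compound 4 (0.60 log units; beyond the scatter), so the choice of five-membered aromatic ring on this carbon, opposite the ring nitrogen, can shift the number beyond the scatter. Among these compounds, the two groups have the same counts of hydrogen-bond donors and acceptors, so those counts alone do not predict the step, and the earlier compounds could not show this because no two of them differ in one place. Nothing measured here accounts for the step.

The exchange alters the ring and adds a methyl together, so the compounds shown leave open which of the two carries the step. A plain 1,3-thiazol-2-yl group, or an ethyl group or a chlorine atom in place of the methyl, would help separate them.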